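A few compounds are considered here, and "the series" means these few. Any claim that something is new, unique, unknown or untested is made for them only; others in the source may bear on it.

In a functional assay on KB cells (Homo sapiens) for cytotoxicity (a higher number here means a weaker inhibitor, a lower number a stronger inhibitor), compound 1 (`Cc1ccc(S(=O)(=O)N/C(=N\O)Nc2ccc(Cl)cc2)cc1`) gives 46 ug/mL and compound 2 (`O=S(=O)(N/C(=N\O)Nc1ccc(Cl)cc1)c1cccc2snnc12`) gives 35 ug/mL, two values within the usual scatter of each other. Compound 3 (`CCCCOc1ccc(S(=O)(=O)N/C(=N\O)Nc2ccc(Cl)cc2)cc1`) keeps the core of compound 1 but carries butoxy in place of methyl on an aromatic carbon, para to a large group: butoxy in place of methyl on an aromatic carbon. Going by the values given here, no measured pair shows this kind of change, so only a cautious expectation is possible. The estimated step is modest and points toward a lower number, a 1.5-fold lower number from compound 1 to compound 3 (0.19 log units; within the scatter). For compound 3 the expected value is 30 ug/mL, with a likely range from 12 ug/mL to 75 ug/mL.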

Compound 3, half-maximal inhibitory concentration: 50 ug/mL
Compound 3: the middle estimate sits 1.7-fold (0.22 log units) below what was measured; the range from low to high includes it.
By their numbers in this assay, from the lowest: compounds 2, 1 and 3 (each within the scatter of the next).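

In this assay putting butoxy in place of methyl on this aromatic carbon gives a 1.1-fold higher number from compound 1 to compound 3 (0.04 log units; within the scatter) and so leaves the two compounds indistinguishable. At this position, para to a large group, a chain with an oxygen and more heavy atoms is therefore accepted without a readable shift in cytotoxicity. Nothing available explains why the two compounds read alike. Open, on these data alone, is whether an amine or a carboxylic acid at this position would also stay within the scatter of compound 1, and whether a chain longer than butoxy would.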